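The compounds below may be only part of what the source reports. "The series", "measured", "known", "first", "only" and "open" are said of these compounds alone.

Going by the values given here, in a functional assay on A549 cells (Homo sapiens) for cytotoxicity, read by MTT assay, with a stated time of 72 h (on this read-out lower numbers stand for stronger inhibition and higher numbers for weaker inhibition), compound 2 `Cn1ccc2c(Oc3ccc(NC(=O)c4cc5cccnc5n(-c5ccc(C(F)(F)F)c(Cl)c5)c4=O)cc3F)ncnc21` gives 320000 nM as the higher of the two numbers so far, and compound 1 `Cn1ccc2c(Oc3ccc(NC(=O)c4cc5cccnc5n(-c5ccc(Br)cc5)c4=O)cc3F)ncnc21` gives 42200 nM as the lower. Compound 3 `Cn1ccc2c(Oc3ccc(NC(=O)c4cc5cccnc5n(-c5ccc(C(F)(F)F)cc5Cl)c4=O)cc3F)ncnc21` carries 2-chloro-4-(trifluoromethyl)phenyl in place of 3-chloro-4-(trifluoromethyl)phenyl on an aromatic nitrogen, a change counted as 2-chloro-4-(trifluoromethyl)phenyl in place of 3-chloro-4-(trifluoromethyl)phenyl on an aromatic nitrogen and joining the same atoms differently. Among the compounds with values here, the only measured step at that nitrogen is a 7.6-fold higher number from compound 1 to compound 2 (0.88 log units; beyond the scatter) and it is modest, and no measured pair moves the chlorine alone. The expected change is smaller and toward lower numbers, estimated as a 1.9-fold lower number from compound 2 to compound 3 (0.27 log units; within the scatter) for now. Compound 3 is estimated at 170000 nM with an expected range from 45000 nM to 500000 nM.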

Compound 3, half-maximal inhibitory concentration: "not active" (no number reported)
Nothing numeric was reported for compound 3; no gap can be computed for the estimate.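

Going by these compounds alone, compound 3 is reported as "not active", with no number, in this assay, so no step from compound 2 to compound 3 can be read. The compounds shown leave open how far moving the chlorine shifts the number. No measurement shown bears on this result.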